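Aryl group swap on the shared core: compound 2 to compound 3

The compounds below may be only part of what the source reports. "The series", "measured", "known", "first", "only" and "open" are said of these compounds alone.

Among the compounds with values here, in a functional assay on A-431 cells (Homo sapiens) (a lower number here means that less compound is needed, a higher number that more compound is needed for the effect), compound 1 `COc1cc(OC)cc(Oc2ncccc2-c2n[nH]c(Nc3cccc(O)c3)n2)c1` gives 10 nM and compound 2 `COc1cc(OC)cc(Oc2ncccc2-c2n[nH]c(Nc3ccc4c(c3)OCCO4)n2)c1` gives 3.6 nM as the lowest of the two numbers so far. Within the data shown here, the single measured step (a 2.8-fold lower number from compound 1 to compound 2 (0.44 log units; beyond the scatter)) brought 2,3-dihydro-1,4-benzodioxin-6-yl in place of 3-hydroxyphenyl on a nitrogen on an aromatic ring. It is modest but beyond the scatter.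

Compound 3 `COc1cc(OC)cc(Oc2ncccc2-c2n[nH]c(Nc3ccc(N(C)C)cc3)n2)c1` keeps the shared core and changes that same place, with 4-(dimethylamino)phenyl in place of 2,3-dihydro-1,4-benzodioxin-6-yl (4-(dimethylamino)phenyl in place of 2,3-dihydro-1,4-benzodioxin-6-yl on a nitrogen on an aromatic ring). Among the measured compounds shown here, that one step is the only guide. For the measured compounds named here, it shows that the number in this assay moves with the group at this place, but no measured compound carries the entering group. With compound 2 at the low end of a two-compound range, any drift seems more likely towards a higher number, and a large change has no support in the data. The estimate is a 1.7-fold higher number from compound 2 to compound 3 (0.22 log units; within the scatter) and no clear step beyond the scatter is expected. For compound 3 the expected value is 6 nM within a range from 2 nM to 20 nM in this assay.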

Compound 3, half-maximal effective concentration: 31 nM
Estimate against measurement, compound 3: 5.2-fold (0.71 log units) below; measured number outside the range, above it.
By their numbers in this assay, from the lowest: compound 2; then compound 1; then compound 3.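

In this assay, within the data shown here, the place on the nitrogen now shows movement in both directions: an 8.6-fold higher number from compound 2 to compound 3 (0.94 log units; beyond the scatter) with 4-(dimethylamino)phenyl entering, whereas the only earlier step, a 2.8-fold lower number from compound 1 to compound 2 (0.44 log units; beyond the scatter), went the other way. The entering group also stands apart from the 3-hydroxyphenyl group, with a 3.1-fold higher number from compound 1 to compound 3 (0.49 log units; beyond the scatter), so among these three groups compound 3 has the highest number, and the two compounds with oxygen on the aryl group both lie lower than the one with a dimethylamino nitrogen. No measurement at hand accounts for this rise.

The three compounds leave open whether the higher number goes with the dimethylamino group itself or with the replacement of the oxygen-bearing aryl groups as a whole, and a primary amine or a methoxy group on the same phenyl ring would bear on that question. From the compounds shown here alone, it also remains open whether this order of the three groups holds on any core other than the shared one.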